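A Dimethoxyphenyl Swap at the Cytotoxicity Ceiling

The compounds below may be only part of what the source reports. "The series", "measured", "known", "first", "only" and "open" are said of these compounds alone.

Three compounds from one series were tested in an ADME assay on NCM460 cells (Homo sapiens) for cytotoxicity, read by MTT assay, with a stated time of 72 h; on this read-out lower numbers stand for stronger inhibition and higher numbers for weaker inhibition. Compound 1 `Cc1ccc(N2C(=O)C/C(=C\c3cccc(C(=O)Nc4cccc(F)c4)c3)C2=O)cc1` gave > 100000 nM, which is a limit of the assay rather than a number. Compound 2 `Cc1ccc(NC(=O)c2cccc(/C=C3\CC(=O)N(c4ccccc4)C3=O)c2)cc1C` gave > 100000 nM, again a limit. Compound 3 `COc1cc(NC(=O)c2cccc(/C=C3\CC(=O)N(c4ccccc4)C3=O)c2)cc(OC)c1OC` gave > 100000 nM, once more a limit. Among the measured compounds shown here, compound 2 therefore stands exactly where every other measured compound stands, namely at the limit of > 100000 nM in this assay, at which 3 of the 3 values shown sit; since no compound in this set has a measured number, no ordering among them can be drawn.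

The step under consideration leads from compound 2 to compound 4 `COc1ccc(OC)c(NC(=O)c2cccc(/C=C3\CC(=O)N(c4ccccc4)C3=O)c2)c1`, which is not yet measured in this assay. The change is 2,5-dimethoxyphenyl in place of 3,4-dimethylphenyl on an amide-type nitrogen. Nothing else in the structure moves.

For the measured compounds named here, no step between measured compounds is available to size this change. With all three measured values resting at the same limit, the expectation is for no step beyond the scatter. The step of a number no higher from compound 2 to compound 4 (the limit leaves the size open) is therefore expected to be flat. The estimate for compound 4 in this assay is 100000 nM, with a range from 50000 nM to 200000 nM, and the assay is expected most likely to report only a limit once more.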

Compound 4, half-maximal inhibitory concentration: > 100000 nM
Compound 4 ended at the assay's limit; the forecaster's own chance of this, stated with the estimate: 85%; the middle value sits exactly at the limit.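

No step can be read between compound 2 and compound 4 in this assay, because each gives only a limit of the assay rather than a number: the limit of > 100000 nM in this assay, at which 4 of the 4 values shown sit.

The compounds shown leave open how 2,5-dimethoxyphenyl and 3,4-dimethylphenyl truly compare on the amide-type nitrogen, and what actual cytotoxicity value any of these four compounds has.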